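The source may hold more compounds than are shown below. What is called first, only, known or untested is meant among the compounds shown, and "the series" means these compounds.

In a functional assay on HCT-116 cells (Homo sapiens) for cytotoxicity, read by MTT assay (a higher number here means a weaker inhibitor, a lower number a stronger inhibitor), compound 1 (`Cc1cc(O)c(C(=O)/C=C/c2ccccc2)c(=O)o1`) gives > 100000 nM as a limit and not a number. Compound 2 (`Cc1cc(O)c(C(=O)/C=C/c2cccs2)c(=O)o1`) gives > 100000 nM which is also a limit. Compound 3 (`Cc1cc(O)c(C(=O)/C=C/c2ccc[nH]2)c(=O)o1`) gives > 100000 nM which is again a limit. Compound 1 therefore has no exact position, and it shares the limit of > 100000 nM in this assay, at which 3 of the 3 values shown sit, with the other two compounds.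

Compound 4 (`Cc1cc(O)c(C(=O)/C=C/c2ccc(F)cc2)c(=O)o1`) differs from compound 1 by one substitution on the aromatic ring (fluoro in place of hydrogen on an aromatic carbon) with fluoro in place of hydrogen on an aromatic carbon. The closest measured changes replace the whole phenyl group. These are a step that the two limits leave unreadable from compound 1 to compound 2 and a step that the two limits leave unreadable from compound 1 to compound 3 and neither has a readable size, while neither replacement yielded a measured number. They give no sign of a gain, so no step beyond the scatter is expected in this assay for the fluoro change. The expected step is a number no higher from compound 1 to compound 4 (the limit leaves the size open) in no clear direction. For compound 4 the estimated value is 100000 nM with an expected range from 45000 nM to 220000 nM and another limit is the likeliest report.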

Compound 4, half-maximal inhibitory concentration: > 100000 nM
Compound 4 gave a limit, no number; the forecaster's own chance of this, stated with the estimate: 80%; the middle value sits exactly at the limit.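

No step can be read between compound 1 and compound 4, because both results in this assay are limits and not numbers: the limit of > 100000 nM in this assay, at which 4 of the 4 values shown sit.

The compounds shown leave open whether the fluoro group, or either replacement of the phenyl group, changes the result in this assay at all.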